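A few compounds are considered here, and "the series" means these few. Any claim that something is new, unique, unknown or untested is made for them only; others in the source may bear on it.

Compound 2 `COc1cc(-c2cc(C(=O)O)c3ccccc3n2)ccc1OCC(=O)Nc1ccc(Cl)cc1` sits at a limit in an ADME assay on HaCaT cells (Homo sapiens) for inhibition (a higher number here means a weaker inhibitor, a lower number a stronger inhibitor), where it gives > 300000 nM. Compound 1 `COc1cc(-c2cc(C(=O)O)c3ccccc3n2)ccc1OCC(=O)Nc1ccccc1C` in this assay gives 230000 nM. Within the data shown here, the single measured step, an at least 1.3-fold higher number from compound 1 to compound 2 (0.11 log units; that floor lies within the scatter), is open-ended because of the limit of > 300000 nM in this assay, at which 1 of the 2 values shown sits, so only its floor is known. Compound 3 `COc1cc(-c2cc(C(=O)O)c3ccccc3n2)ccc1OCC(=O)NCc1cccs1` differs from compound 2 by (thiophen-2-yl)methyl in place of 4-chlorophenyl on an amide-type nitrogen. Among the measured compounds shown here, no measured step covers this change, and with both known values so high, the estimated step of a number no higher from compound 2 to compound 3 (the limit leaves the size open) is expected to stay within the scatter, in no clear direction. Compound 3 is therefore expected to give 300000 nM in this assay, with a range of 120000 nM to 700000 nM.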

Compound 3, half-maximal inhibitory concentration: > 300000 nM
Compound 3 ended at the assay's limit; the forecaster's own chance of this, stated with the estimate: 50%; the middle value lies on the limit itself.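

In this assay, (thiophen-2-yl)methyl on the amide-type nitrogen joins 4-chlorophenyl at the limit, so a five-membered aromatic ring with a hetero atom also gives no readable value at this position. Against 2-methylphenyl, the change gives an at least 1.3-fold higher number from compound 1 to compound 3 (0.11 log units; that floor lies within the scatter), so it shows no clear order. The step linking compound 2 and compound 3 cannot be read, and the values of both are limits: the limit of > 300000 nM in this assay, at which 2 of the 3 values shown sit.

Going by these compounds, it remains open whether an amine or a longer chain on this nitrogen would give a value inside the range of this assay. On these data alone, how far compound 2 and compound 3 lie past the limit also remains unknown.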